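Moving the Methyl Pyrazole Attachment Point in an Aryl Amine Series

This account rests on a few compounds, and the source may have more. Where it says the series, first, only, none or still open, it means among the compounds named here.

Compound 3 `Cn1nccc1-c1ccccc1NCC1=NCCN1` is known only through a limit: in an in vitro functional assay on cells (Fibroblast) for agonist activity at Alpha-1D adrenergic receptor (Homo sapiens) (a lower number here means that less compound is needed, a higher number that more compound is needed for the effect), compound 3 gives < 100000 nM, which is a limit of the assay and not a number. For the measured compounds named here, compound 1 `Cn1ncnc1-c1ccccc1NCC1=NCCN1` is the one neighbour with a plain value; in this assay compound 1 gives 63.1 nM. Compound 2 `Cc1n[nH]c(-c2ccccc2NCC2=NCCN2)n1` also carries a limit; in this assay compound 2 gives < 5020 nM. The three steps among these compounds, a step that the limit leaves unreadable from compound 1 to compound 2, a step that the limit leaves unreadable from compound 1 to compound 3 and a step that the two limits leave unreadable from compound 2 to compound 3, cannot be sized because of the limit of < 100000 nM in this assay, at which 1 of the 3 values shown sits, and (the limit of < 5020 nM in this assay, at which 1 of the 3 values shown sits).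

Compound 4 `Cn1ccc(-c2ccccc2NCC2=NCCN2)n1` differs from compound 3 in one place: 1-methyl-1H-pyrazol-3-yl in place of 1-methyl-1H-pyrazol-5-yl on an aromatic carbon. Going by the values given here, no measured pair swaps these two attachment points of the methyl pyrazole, so no step gives the direction or size of the change, and compound 3 itself stands at a limit, so even the starting point is uncertain. The expected step is a step that the limit leaves unreadable from compound 3 to compound 4, taken as no change beyond the usual scatter but with a wide range around it. Compound 4 is therefore expected to give about 10000 nM in this assay, within 500 nM to 100000 nM, and it may well return only a limit.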

Compound 4, half-maximal effective concentration: 15.9 nM
Compound 4: the middle estimate sits 630-fold (2.80 log units) above what was measured; the whole stated range lies above it.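

Compound 4 gives a plain value of 15.9 nM in this assay, which shows that a 1-methyl-1H-pyrazol-3-yl group on this aromatic carbon, ortho to a group of 7 heavy atoms, is compatible with a measurable effect. Exchanging the 1-methyl-1H-1,2,4-triazol-5-yl group for this pyrazole gives a 4.0-fold lower number from compound 1 to compound 4 (0.60 log units; beyond the scatter), so compound 1 no longer holds the lowest number among the compounds with plain values, and a ring with 2 hetero atoms can serve here as well as the triazole. Compound 2 and compound 3 are known only through limits, so the steps from each of them to compound 4 cannot be read: the limit of < 100000 nM in this assay, at which 1 of the 4 values shown sits.

The compounds shown therefore leave open how large the effect of moving the attachment point of the methyl pyrazole really is, even though compound 3 and compound 4 contain the same atoms joined differently. As far as these compounds go, it also remains open what an ethyl group in place of the methyl of the 1-methyl-1H-pyrazol-3-yl group, or an amine on that ring, would do to the number in this assay.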